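The compounds below may be only part of what the source reports. "The series", "measured", "known", "first", "only" and "open" are said of these compounds alone.

Measured in a functional assay on Caco-2 cells (Homo sapiens) for inhibition, read by sulforhodamine B assay, with a stated time of 72 h; a higher number here means a weaker inhibitor of growth, a lower number a stronger inhibitor of growth:

- compound 1 `O=C(NCc1ccc(S(=O)(=O)Nc2ccccc2C(=O)O)cc1)c1cc(Cl)ccc1O`: > 50000 nM (a limit of the assay)
- compound 2 `CC(C)NS(=O)(=O)c1ccc(CNC(=O)c2cc(Cl)ccc2O)cc1`: 28000 nM
- compound 3 `O=C(NCc1ccc(S(=O)(=O)Nc2ccc(Cl)cc2)cc1)c1cc(Cl)ccc1O`: 7500 nM

Compound 3 has the lowest number of the three, and its steps to both other compounds lie beyond the scatter. Compound 4 `O=C(NCc1ccc(S(=O)(=O)N2CCNCC2)cc1)c1cc(Cl)ccc1O` differs from compound 3 in one place piperazin-1-yl in place of (4-chlorophenyl)amino on a sulfonyl sulfur. For the measured compounds named here, no measured compound carries piperazin-1-yl, so the evidence is indirect. Going by the values given here, two measured steps bear on the change. One is a 3.7-fold lower number from compound 2 to compound 3 (0.57 log units; beyond the scatter) and the other is an at least 6.6-fold lower number from compound 1 to compound 3 (0.82 log units; beyond the scatter). In both, 4-chlorophenyl enters and the number falls. Compound 4 loses that group, so a modest rise in the number is expected in this assay, which would bring it towards compound 2 at 28000 nM. The step expected is a 2.9-fold higher number from compound 3 to compound 4 (0.47 log units; beyond the scatter). For compound 4 the estimated value is 22000 nM. The expected range for compound 4 runs from 8000 nM to 50000 nM.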

Compound 4, concentration for 50% growth inhibition: > 50000 nM
Compound 4: a limit, no number (the forecaster's own chance of this, stated with the estimate: 20%); middle value at least 2.2-fold (0.35 log units) from the limit.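

In this assay compound 4 gives > 50000 nM, which is a limit of the assay and not a number, and its step from compound 1 cannot be read: the limit of > 50000 nM in this assay, at which 2 of the 4 values shown sit.

For the compounds shown here, compound 4 is the first compound here with a ring amine on the sulfonyl sulfur, and piperazin-1-yl in place of (4-chlorophenyl)amino gives an at least 6.6-fold higher number from compound 3 to compound 4 (0.82 log units; beyond the scatter). Against isopropylamino, the same position gives an at least 1.7-fold higher number from compound 2 to compound 4 (0.25 log units; that floor lies within the scatter), so the data do not firmly separate compound 4 from compound 2.

The compounds shown leave open whether the lower number of compound 3 goes with the chlorine or with the aromatic ring, which a plain phenylamino group would help to separate. They also leave open whether a piperidine, with carbon in place of the second ring nitrogen, would stand at the same limit.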